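Cytotoxicity of Two Aryl Ethers and a Phenoxy Analogue

A few compounds are considered here, and "the series" means these few. Any claim that something is new, unique, unknown or untested is made for them only; others in the source may bear on it.

Measured compounds:
Compound 1, `CN1Cc2ccc(OCCc3ccccc3)cc2[C@@H](O)C1`, in an ADME assay on Vero cells (Chlorocebus sabaeus) for cytotoxicity, read by sulforhodamine B assay, with a stated time of 72 h (a higher number here means a weaker inhibitor, a lower number a stronger inhibitor), gives > 50000 nM.
Compound 2, `CN1Cc2ccc(OCC3CCNCC3)cc2[C@@H](O)C1`, gives > 100000 nM.

Both readings are limits of the assay rather than numbers. Compound 1 stands at the limit (the limit of > 50000 nM in this assay, at which 1 of the 2 values shown sits). Compound 2 stands at the limit (the limit of > 100000 nM in this assay, at which 1 of the 2 values shown sits). Going by the values given here, because both are limits, the single measured step, a step that the two limits leave unreadable from compound 1 to compound 2, cannot be read in size or direction.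

Compound 3, `CN1Cc2ccc(OCCOc3ccccc3)cc2[C@@H](O)C1`, differs from compound 1 as follows: phenoxy in place of phenyl on a saturated chain carbon, two bonds along the chain from an oxygen on an aromatic ring. Among the compounds with values here, no measured step touches this change, and the one step available is unreadable, so nothing points to a shift beyond the scatter. The expected step is therefore a step that the limit leaves unreadable from compound 1 to compound 3. Compound 3 is expected to give about 100000 nM, in a range from 30000 nM to 300000 nM, most likely reported once more only as a limit.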

Compound 3, half-maximal inhibitory concentration: > 100000 nM
Compound 3: only a limit was reported; the forecaster's own chance of this, stated with the estimate: 85%; the middle value sits exactly at the limit.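

Compound 1 and compound 3 are both reported only as limits, so the step between them cannot be read in size or direction. Still open, from the compounds shown here alone, is where the true values of compound 1, compound 2 and compound 3 lie in this assay, and whether phenoxy in place of phenyl changes anything there.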